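This account rests on a few compounds, and the source may have more. Where it says the series, first, only, none or still open, it means among the compounds named here.

Compound 2 `CC(=O)c1cnc(N2CCC(c3coc4c(N5CCc6cc(S(C)(=O)=O)ccc65)ncnc34)CC2)nc1` shows the smallest maximal response of the three measured compounds in a functional assay on cells for agonist activity at Glucose-dependent insulinotropic receptor (Homo sapiens), read by a luciferase reporter, with a stated time of 4 h; a lower number here means a smaller maximal response, a higher number a larger maximal response: compound 2 reaches 12%. Compound 1 `CS(=O)(=O)c1ccc2c(c1)CCN2c1ncnc2c(C3CCN(c4ncccn4)CC3)coc12` reaches 196%; it carries hydrogen where compound 2 carries acetyl. Compound 3 `CC(C)(C)OC(=O)N1CCC(c2csc3c(Nc4ccc(S(C)(=O)=O)cc4F)ncnc23)CC1`, built on a different core, reaches 82%. Among the compounds with values here, the one measured step that bears on the present change is a number 184 percentage points lower from compound 1 to compound 2 (beyond the scatter). Compound 4 `COc1cnc(N2CCC(c3coc4c(N5CCc6cc(S(C)(=O)=O)ccc65)ncnc34)CC2)nc1` differs from compound 2 by methoxy in place of acetyl on an aromatic carbon. Because a number 184 percentage points lower from compound 1 to compound 2 (beyond the scatter) shows the arrival of acetyl costing a great deal, a rise is expected once acetyl leaves, though a single step cannot fix its size. Compound 4 is therefore estimated at 90%, between 20% and 180%, an expected step of a number 78 percentage points higher from compound 2 to compound 4 (beyond the scatter).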

Compound 4, largest response reached (Emax), in percent of the reference or control that the assay uses: 186%
Compound 4: the middle estimate sits 96 percentage points below what was measured; measured number outside the range, above it.
By their numbers in this assay, from the lowest: compound 2; then compound 3; then compounds 4 and 1 (each within the scatter of the next).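

Methoxy in place of acetyl on this aromatic carbon gives a number 174 percentage points higher from compound 2 to compound 4 (beyond the scatter) in this assay and so shows that the low response of compound 2 is not shared by every group at this position. Methoxy in place of hydrogen gives a number 10 percentage points lower from compound 1 to compound 4 (within the scatter) and this step stays within the scatter. Nothing shown explains why acetyl and methoxy differ so sharply. From the compounds shown here alone, it remains open whether an amine, a carboxylic acid or a longer alkoxy chain on this carbon would behave like methoxy or like acetyl.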